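Chloro for Fluoro on the Fused Ring of Compound 3

The source may hold more compounds than are shown below. What is called first, only, known or untested is meant among the compounds shown, and "the series" means these compounds.

Measured compounds:
Compound 1 `O=C(O)CC(Cc1nc2cc(Cl)ccc2[nH]1)c1ccc(Cl)cc1` — 0%
Compound 2 `O=C(O)CC(Cc1nc2cc(F)ccc2[nH]1)c1ccc(Cl)cc1` — 0%
Compound 3 `O=C(O)CC(Cc1nc2cc(F)c(F)cc2[nH]1)c1ccc(Cl)cc1` — 15%

Three compounds share a core and were tested in an assay on isolated protein for inhibition of protein kinase C zeta type (Homo sapiens), read by 33P incorporation, tested at 50 uM; on this read-out lower numbers stand for a weaker effect and higher numbers for a stronger effect at the one concentration tested. Compound 1 gives 0% and compound 2 gives 0%; the step of no change at the digits printed from compound 1 to compound 2 (within the scatter) shows that swapping chloro for fluoro on the fused ring leaves the number where it was. Among the measured compounds shown here, compound 3 gives 15%, and a number 15 percentage points higher from compound 2 to compound 3 (beyond the scatter) is the one step beyond the scatter. On these three numbers compound 3 stands highest, with both compound 1 and compound 2 lower by a gap beyond the scatter.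

Compound 4 `O=C(O)CC(Cc1nc2cc(Cl)c(F)cc2[nH]1)c1ccc(Cl)cc1` has not been measured. It differs from compound 3 by chloro in place of fluoro on an aromatic carbon, the change sitting on an aromatic carbon of the six-membered ring of carbon only, ortho to a fluoro group. The step that bears on it most directly is no change at the digits printed from compound 1 to compound 2 (within the scatter), the same kind of halogen exchange on the same ring, which brought no change. The step of a number 15 percentage points higher from compound 2 to compound 3 (beyond the scatter) was modest, and compound 4 keeps both ring substituents. Compound 4 is therefore expected to show no step beyond the scatter in this assay, no change at the digits printed from compound 3 to compound 4 (within the scatter), and its estimated value is 15%, ranging from 0% to 30%.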

Compound 4, a percentage reported as inhibition, at one concentration (the size of the read-out at that concentration, not a potency): 35%
Compound 4: the middle estimate sits 20 percentage points below what was measured; measured number outside the range, above it.
By their numbers in this assay, from the lowest: compounds 1 and 2 (each within the scatter of the next); then compound 3; then compound 4.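

In this assay, chloro in place of fluoro at this position gives a number 20 percentage points higher from compound 3 to compound 4 (beyond the scatter), so the halogen here matters once a fluoro group stands ortho to it, although the exchange on the core of compound 1 moved nothing: the same change on two cores in this assay, no change at the digits printed (within the scatter) from compound 1 to compound 2 and a number 20 percentage points lower (beyond the scatter) from compound 4 to compound 3, 20 percentage points apart, beyond the scatter of two such steps. Fluoro in place of hydrogen also depends on the halogen already on the ring, giving a number 35 percentage points higher from compound 1 to compound 4 (beyond the scatter) where the same change on compound 2 gave a number 15 percentage points higher from compound 2 to compound 3 (beyond the scatter): the same change on two cores in this assay, a number 15 percentage points higher (beyond the scatter) from compound 2 to compound 3 and a number 35 percentage points higher (beyond the scatter) from compound 1 to compound 4, 20 percentage points apart, beyond the scatter of two such steps. The two ring substituents therefore do not act independently on this read-out.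

From the compounds shown here alone, whether bromo or methyl at this position would raise the number further remains open, as does what happens when an amide replaces the carboxylic acid. Compound 4 gives 35% at one concentration, which is no potency.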